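From Compound 1 to Compound 3 in Rat Aorta

A few compounds are considered here, and "the series" means these few. Any claim that something is new, unique, unknown or untested is made for them only; others in the source may bear on it.

Of the compounds shown here, two sharing the same core have so far been tested in a functional assay (aorta) with Rattus norvegicus as the target; on this read-out higher numbers stand for an effect only at larger amounts of compound and lower numbers for an effect already at smaller amounts. Compound 1, with the structure `COc1ccc(-c2nc(/N=C(\N)N3CCOCC3)sc2-c2ccc(OC)cc2)cc1`, gives 66 uM in this assay, the highest of the two numbers. Compound 2, with the structure `COc1ccc(-c2nc(C(=O)N3CCCCC3CCO)sc2-c2ccc(OC)cc2)cc1`, gives 6.8 uM in this assay, a markedly lower number that lies beyond the scatter of the method. Compound 3, with the structure `COc1ccc(-c2nc(/C=C/C(=O)O)sc2-c2ccc(OC)cc2)cc1`, has not yet been measured in this assay.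

Compound 3 differs from compound 1 in a single place: a group of 5 heavy atoms (3 carbon, 2 oxygen; no ring) in place of a group of 9 heavy atoms (5 carbon, 3 nitrogen, 1 oxygen; one six-membered non-aromatic ring with 2 hetero atoms), on an aromatic carbon. The changed group sits on the same aromatic carbon of the core at which compound 2 also differs from compound 1.

For the measured compounds named here, no measured pair shows this exact change, so the direction of the step is uncertain. Because compound 2 gives 6.8 uM after a different group was placed at the same carbon, compound 3 is expected to give a somewhat lower number than compound 1, a step of about a 2.2-fold lower number from compound 1 to compound 3 (0.34 log units; beyond the scatter) in this assay. The estimate for compound 3 in this assay is 30 uM, with a likely range from 8 uM to 120 uM.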

Compound 3, concentration for half-maximal effect: 55 uM
Compound 3: middle estimate off by 1.8-fold (0.26 log units), on the low side; measured number inside the range.
By their numbers in this assay, from the lowest: compound 2; then compounds 3 and 1 (each within the scatter of the next).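

At this aromatic carbon, next to the ring nitrogen and next to the ring sulfur, 2-carboxyethenyl in place of the group of 9 heavy atoms with its six-membered ring gives a 1.2-fold lower number from compound 1 to compound 3 (0.08 log units; within the scatter) in this assay. Two groups that differ in size, in ring content and in their atoms thus leave the number within the scatter, which the earlier pair of compounds could not show. A new group at this carbon therefore does not by itself bring the low number of compound 2, 6.8 uM, since compound 3 gives 55 uM and stays within the scatter of compound 1; nothing available here explains this result.

As far as these compounds go, what remains open is which part of the group in compound 2 goes with its lower number, the amide link or the hydroxyethyl chain. A simple unsubstituted amide or a methyl ester at this carbon would be needed to separate these parts from the carboxylic acid of compound 3, and a saturated propanoic acid chain would show whether the double bond of 2-carboxyethenyl matters.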